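The source may report more compounds than this note shows. Statements on the series, on what has been measured and on what is new or still open speak of the compounds shown alone.

Among the compounds with values here, compound 1 `CCOc1ccc(-c2cc(C(=O)O)nn2-c2ccc(Oc3ccccc3)cc2)cc1` gives 694 nM in an assay for displacement of a labelled ligand from Apoptosis regulator Bcl-2 (Homo sapiens), read by fluorescence polarization, with a stated time of 30 min (on this read-out lower numbers stand for stronger inhibition and higher numbers for weaker inhibition), the lowest of the two numbers known so far, with compound 2 `CC(C)Oc1ccc(-c2cc(C(=O)O)nn2-c2ccc(Oc3ccccc3)cc2)cc1` giving 932 nM and the step of a 1.3-fold higher number from compound 1 to compound 2 (0.13 log units; within the scatter) lying within the scatter. Compound 3 `CCOc1ccc(-c2c(NC(=O)c3ccccc3)c(C(=O)O)nn2-c2ccc(Oc3ccccc3)cc2)cc1` carries benzamido in place of hydrogen on an aromatic carbon. Within the data shown here, no measured step touches that aromatic carbon; the one step known, a 1.3-fold higher number from compound 1 to compound 2 (0.13 log units; within the scatter), changes only the ether chain and offers no guide to a benzamido group there. Compound 3 is therefore expected to show a 1.5-fold lower number from compound 1 to compound 3 (0.19 log units; within the scatter), a step that need not clear the scatter. The estimate for compound 3 is 450 nM, between 90 nM and 2200 nM.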

Compound 3, inhibition constant: 855 nM
Compound 3: the middle estimate sits 1.9-fold (0.28 log units) below what was measured, within the range that was stated.
By their numbers in this assay, from the lowest: compounds 1, 3 and 2 (each within the scatter of the next).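

In this assay, putting benzamido in place of hydrogen on this aromatic carbon of the five-membered ring gives a 1.2-fold higher number from compound 1 to compound 3 (0.09 log units; within the scatter). The earlier compounds shown here showed only a step in the ether chain; this result shows that a group of 9 heavy atoms can stand at this carbon, next to the ring atom that bears a carboxy group, with the two numbers still within the scatter. No measured evidence bears on this result. The compounds shown leave open whether an amine or an acetamido group on the same carbon would give a step beyond the scatter.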